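Swapping a halogen for trifluoromethyl on the pendant phenyl

A few compounds are considered here, and "the series" means these few. Any claim that something is new, unique, unknown or untested is made for them only; others in the source may bear on it.

Two compounds share a core and differ only in the group on the outer phenyl ring. Compound 1 `Fc1ccc(-c2cn3ccnc3c(-c3ccc4ncn(C5CCCCC5)c4c3)n2)cc1` carries a fluoro there, and in a functional assay on MDA-MB-231 cells (Homo sapiens) for inhibition, read by sulforhodamine B assay, with a stated time of 48 h, tested at 10 uM (a lower number here means less inhibition, a higher number more inhibition at the concentration tested (going by the name of the read-out)), compound 1 gives 15.8%. Compound 2 `Brc1ccc(-c2cn3ccnc3c(-c3ccc4ncn(C5CCCCC5)c4c3)n2)cc1` carries a bromo in the same spot, and in this assay compound 2 gives 22.8%. The step of a number 7 percentage points higher from compound 1 to compound 2 (within the scatter) lies within the scatter, so these two numbers cannot be told apart; compound 2 stands beside compound 1 with no measured neighbour that differs from it beyond the noise.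

Compound 3 `FC(F)(F)c1cccc(-c2cn3ccnc3c(-c3ccc4ncn(C5CCCCC5)c4c3)n2)c1` has not yet been tested. It differs from compound 2 as follows: 3-(trifluoromethyl)phenyl in place of 4-bromophenyl on an aromatic carbon. Among the compounds with values here, the only measured step that bears on this change is the one from compound 1 to compound 2, and that was within the scatter. Within the data shown here, nothing measured so far points to a real move in this assay when the group on the outer phenyl is exchanged. Compound 3 is therefore expected to give about 22%, with a range from 8% to 38%. The expected step of a number 0.8 percentage points lower from compound 2 to compound 3 (within the scatter) is estimated to stay within the scatter.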

Compound 3, a percentage reported as inhibition, at one concentration (the size of the read-out at that concentration, not a potency): 21.8%
The estimate for compound 3 lay 0.2 percentage points above the measured number; measured number inside the range.
By their numbers in this assay, from the lowest: compounds 1, 3 and 2 (each within the scatter of the next).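

The outer phenyl group at this position can be exchanged more widely than the fluoro and bromo pair suggested. In this assay, putting 3-(trifluoromethyl)phenyl in place of 4-bromophenyl gives a number 1 percentage points lower from compound 2 to compound 3 (within the scatter) and putting it in place of 4-fluorophenyl gives a number 6 percentage points higher from compound 1 to compound 3 (within the scatter) in a second reading of the same exchange, so all three compounds remain within the scatter of one another, even though the entering group has 10 heavy atoms against 7 for 4-bromophenyl and its substituent sits at a different place on the phenyl ring. No independent measurement is available to explain why the three numbers cannot be told apart.

Since the group and its place on the ring change together in this step, the data cannot say what either change would do alone. As far as these compounds go, it also remains open whether an amine or a carboxylic acid on the outer phenyl ring, or a longer chain in place of that ring, would move the number beyond the scatter.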